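A Pyrimidine Replaces the Cyclohexyl Group

The source may report more compounds than this note shows. Statements on the series, on what has been measured and on what is new or still open speak of the compounds shown alone.

Compound 2 `CC#C[C@@H](Cc1nnn[nH]1)c1ccc(OCc2ccc3scc(C4CCCCC4)c3c2)cc1` gives 107 nM in a functional assay on cells for agonist activity at Free fatty acid receptor 1 (Homo sapiens), read by FLIPR and calcium flux (a lower number here means that less compound is needed, a higher number that more compound is needed for the effect), the highest of the three numbers measured. Nearest to it stands compound 1 `CC#C[C@@H](Cc1nnn[nH]1)c1ccc(OCc2ccc3scc(-c4cccnc4C)c3c2)cc1`, which gives 88 nM in this assay; the step of a 1.2-fold higher number from compound 1 to compound 2 (0.08 log units; within the scatter) lies within the scatter. Furthest away stands compound 3 `CC#C[C@@H](Cc1nnn[nH]1)c1ccc(OCc2ccc3sc(F)c(-c4ccc(OCCOC)cc4C)c3c2)cc1`, which gives 18 nM in this assay, a number well below that of compound 2.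

Compound 4 `CC#C[C@@H](Cc1nnn[nH]1)c1ccc(OCc2ccc3scc(-c4cncnc4C)c3c2)cc1` differs from compound 2 in one place: 4-methylpyrimidin-5-yl in place of cyclohexyl on an aromatic carbon. Within the data shown here, the only measured step that bears on this change is the one from compound 1 to compound 2, in which a cyclohexyl took the place of a methyl-bearing aromatic ring, and that step was within the scatter. Returning to a methyl-bearing aromatic ring, now with two nitrogens, is therefore expected to give at most a small step in this assay, if any, in the direction of a lower number. The step from compound 2 to compound 4 is estimated at a 1.2-fold lower number from compound 2 to compound 4 (0.08 log units; within the scatter). Compound 4 is expected to give about 90 nM, with a range from 40 nM to 220 nM.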

Compound 4, half-maximal effective concentration: 37 nM
For compound 4 the middle estimate is 2.4-fold (0.39 log units) above the measured one, and the stated range ends above it.
By their numbers in this assay, from the lowest: compound 3; then compound 4; then compounds 1 and 2 (each within the scatter of the next).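

Among these compounds, at this position, on an aromatic carbon two ring bonds from the ring sulfur, the earlier step between 2-methylpyridin-3-yl and cyclohexyl lay within the scatter, so the group placed there had not yet been seen to move the number in this assay at all. The 4-methylpyrimidin-5-yl group does move it: replacing cyclohexyl gives a 2.9-fold lower number from compound 2 to compound 4 (0.46 log units; beyond the scatter) and replacing 2-methylpyridin-3-yl gives a 2.4-fold lower number from compound 1 to compound 4 (0.38 log units; beyond the scatter) in the same direction, so this position responds to the choice of ring and the pyrimidine stands apart from both earlier groups. Nothing measured here accounts for this difference.

Going by these compounds, it remains open whether the methyl on the pyrimidine contributes to these steps. On these data alone, it is also open whether an amine or a longer chain on that ring would lower the number further or raise it again.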